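The source may report more compounds than this note shows. Statements on the series, on what has been measured and on what is new or still open speak of the compounds shown alone.

Two analogues of one shared core have been measured in a functional assay on SF-268 cells (Homo sapiens) for inhibition, read by sulforhodamine B assay, with a stated time of 48 h; on this read-out higher numbers stand for weaker inhibition of growth and lower numbers for stronger inhibition of growth. Compound 1, `CCOC(=O)[C@H](CCC(=O)O)NC(=O)c1ccc(Sc2nc3cc(N)cc(N)c3nc2-c2ccccc2)cc1`, carries an amide-linked ester side chain and gives 16200 nM in this assay. Compound 2, `COc1ccc(Sc2nc3cc(N)cc(N)c3nc2-c2ccccc2)cc1`, carries a methoxy group on the outer benzene ring instead. For compound 2 this assay reports only a limit, < 100000 nM, and not a number. For the measured compounds named here, that limit is the only thing known about compound 2 here, as the limit of < 100000 nM in this assay, at which 1 of the 2 values shown sits, records, so its real position on the scale is open.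

Compound 3, `Nc1cc(N)c2nc(-c3ccccc3)c(Sc3ccc(F)cc3)nc2c1`, is the next step: fluoro in place of methoxy on an aromatic carbon, on an aromatic carbon of a six-membered aromatic ring of carbon only, para to a large group. Going by the values given here, the two neighbours differ in a single substituent, and nothing measured so far shows how this exchange moves the read-out. The step from compound 2 to compound 3 is therefore expected to be small and undecided in direction, at a step that the limit leaves unreadable from compound 2 to compound 3. Compound 3 is estimated to give 30000 nM, likely between 8000 nM and 100000 nM.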

Compound 3, concentration for 50% growth inhibition: 17800 nM
Compound 3: middle estimate off by 1.7-fold (0.23 log units), on the high side, within the range that was stated.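

For the compounds shown here, no step from compound 2 to compound 3 can be read in this assay, because compound 2 has only a limit there and not a number: the limit of < 100000 nM in this assay, at which 1 of the 3 values shown sits.

The compounds shown leave open whether fluoro in place of methoxy on an aromatic carbon changes growth inhibition at all, and if it does, in which direction and by how much.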